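The source may hold more compounds than are shown below. What is called first, only, known or untested is meant among the compounds shown, and "the series" means these compounds.

Measured in a functional assay on the whole organism for inhibition, with Rattus norvegicus as the target, read by paw edema, with stated times of 1 h and 3 h; on this read-out higher numbers stand for an effect only at larger amounts of compound and lower numbers for an effect already at smaller amounts:
- compound 1 `COC(=O)CO/N=C(\C)c1ccc(Br)cc1`: 14 mg/kg
- compound 2 `C/C(=N\OCCC(=O)O)c1ccc(Cl)cc1`: 80 mg/kg
- compound 3 `C/C(=N\OC(C)(C)C(=O)O)c1ccc(Cl)cc1`: 42 mg/kg

Compound 2 stands at 80 mg/kg, within the scatter of compound 3 at 42 mg/kg. Compound 1 at 14 mg/kg carries a lower number than compound 2, beyond the scatter.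

Compound 4 `CNC(=O)CO/N=C(\C)c1ccc(Cl)cc1` has methylcarbamoyl in place of carboxymethyl on a saturated chain carbon bound to an oxygen. Within the data shown here, no measured pair isolates this change, so the expectation rests only on the span of the three values in this assay. A moderate move towards a lower number is expected, near the edge of the scatter. The expected step is a 2.0-fold lower number from compound 2 to compound 4 (0.30 log units; within the scatter). Compound 4 is estimated at 40 mg/kg, with an expected range of 14 mg/kg to 100 mg/kg.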

Compound 4, dose for half-maximal effect: 70 mg/kg
For compound 4 the middle estimate is 1.8-fold (0.24 log units) below the measured one; the measured number falls inside the stated range.
By their numbers in this assay, from the lowest: compound 1; then compounds 3, 4 and 2 (each within the scatter of the next).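

In this assay, methylcarbamoyl in place of carboxymethyl on a saturated chain carbon bound to an oxygen gives a 1.1-fold lower number from compound 2 to compound 4 (0.06 log units; within the scatter). This is the only pair among the compounds shown that differs in one place, and it shows that this exchange at this position produces no step beyond the scatter. No measurement bears on what lies behind this result.

Open, as far as these compounds go, is whether a primary amide, a dimethylcarbamoyl group or a hydroxamic acid at this place would read the same. Also open, from the compounds shown here alone, is how a longer chain carrying methylcarbamoyl would read.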